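Hydrazone aryl variation on a shared triazolylpyridine urea core

This account rests on a few compounds, and the source may have more. Where it says the series, first, only, none or still open, it means among the compounds named here.

Measured so far:
- compound 2 `CN(C)CCn1cnnc1-c1cc(Oc2ccc(NC(=O)N/N=C/c3cccc(Br)c3)cc2F)ccn1` gives 450 nM in a functional assay on MKN-45 cells (Homo sapiens) for cytotoxicity, read by MTT assay, with a stated time of 72 h; on this read-out higher numbers stand for weaker inhibition and lower numbers for stronger inhibition
- compound 1 `CN(C)CCn1cnnc1-c1cc(Oc2ccc(NC(=O)N/N=C/c3ccc(O)c(O)c3)cc2F)ccn1` gives 3240 nM in this assay

Among the measured compounds shown here, compound 2 stands lowest of the two numbers in this assay; compound 1 is its only neighbour and sits well above it. For the measured compounds named here, the single measured step, a 7.2-fold lower number from compound 1 to compound 2 (0.86 log units; beyond the scatter), comes from 3-bromophenyl in place of 3,4-dihydroxyphenyl on a carbon with a double bond to nitrogen.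

Compound 3 `CN(C)CCn1cnnc1-c1cc(Oc2ccc(NC(=O)N/N=C/c3ccc(O)cc3)cc2F)ccn1` is not yet measured. Its difference from compound 2 is 4-hydroxyphenyl in place of 3-bromophenyl on a carbon with a double bond to nitrogen. This change reinstates one hydroxyl on the aryl ring, whereas the measured step removed two and added bromine, so it partly retraces that step. The relevant comparison is therefore compound 1 against compound 2, and the step between them was beyond the scatter. A step upward in this assay is expected, most likely not as large as a 7.2-fold lower number from compound 1 to compound 2 (0.86 log units; beyond the scatter), since the change only partly reverses it. For compound 3 the step expected in this assay is a 3.1-fold higher number from compound 2 to compound 3 (0.49 log units; beyond the scatter). Compound 3 is estimated at 1400 nM, within a range from 500 nM to 4000 nM.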

Compound 3, half-maximal inhibitory concentration: 820 nM
Compound 3: middle estimate off by 1.7-fold (0.23 log units), on the high side; measured number inside the range.
By their numbers in this assay, from the lowest: compounds 2 and 3 (each within the scatter of the next); then compound 1.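

In this assay, 4-hydroxyphenyl in place of 3-bromophenyl on a carbon with a double bond to nitrogen gives a 1.8-fold higher number from compound 2 to compound 3 (0.26 log units; within the scatter), so this exchange does not separate compound 2 from compound 3, and one hydroxy on the aryl ring is compatible with a number in the same range as the bromo compound. The step that does stand out is hydrogen in place of hydroxy on an aromatic carbon, a 4.0-fold lower number from compound 1 to compound 3 (0.60 log units; beyond the scatter), which places much of the gap to compound 1 in this set on the extra hydroxy of the 3,4-dihydroxyphenyl group. No evidence at hand bears on why the numbers fall this way.

The compounds shown leave open whether the kind of substituent or its place on the ring matters more, since 3-bromophenyl and 4-hydroxyphenyl differ in both. An unsubstituted phenyl would give the baseline for both groups, and a methoxy group or an amine on the ring would show whether the hydroxy itself is what counts.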